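This account rests on a few compounds, and the source may have more. Where it says the series, first, only, none or still open, it means among the compounds named here.

In a physicochemical assay for solubility, read by nephelometry, measured as kinetic solubility, at pH 2 (a lower number here means a less soluble compound, a higher number a more soluble compound), compound 2 `COc1ccc(-c2cc(-c3ccc(S(=O)(=O)NC4CC4)cc3)cnc2N)cn1` gives only a limit, > 100 ug/mL. Compound 1 `COc1ccc(-c2cc(-c3ccc(S(N)(=O)=O)cc3)cnc2N)cn1` likewise reaches a limit in this assay, > 100 ug/mL. Among the measured compounds shown here, the step that the two limits leave unreadable from compound 1 to compound 2 is therefore not readable, and the only evidence is the limit of > 100 ug/mL in this assay, at which 2 of the 2 values shown sit. Compound 3 `COc1ccc(-c2cc(-c3ccc(NS(C)(=O)=O)cc3)cnc2N)cn1` differs from compound 2 by methanesulfonamido in place of cyclopropylsulfamoyl on an aromatic carbon. For the measured compounds named here, no measured step bears directly on this change, and both values so far sit at the same limit. Compound 3 is expected to give 150 ug/mL in this assay, within 60 ug/mL to 400 ug/mL. The estimated step that the limit leaves unreadable from compound 2 to compound 3 is thus none beyond the scatter, most likely again reported as a limit.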

Compound 3, solubility: > 100 ug/mL
Compound 3 was reported as a limit; the forecaster's own chance of this, stated with the estimate: 75%; the middle value lies beyond the limit too.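

In this assay compound 3 gives only a limit, > 100 ug/mL. Among the compounds shown here, no step among compound 1, compound 2 and compound 3 can therefore be read: the limit of > 100 ug/mL in this assay, at which 3 of the 3 values shown sit. The compounds shown leave open whether these three differ in solubility at all.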